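Swapping Two Ring Stereocentres in Compound 3

The compounds below may be only part of what the source reports. "The series", "measured", "known", "first", "only" and "open" are said of these compounds alone.

Of the compounds shown here, three have so far been measured in a functional assay on SR cells (Homo sapiens) for inhibition; on this read-out lower numbers stand for stronger inhibition of growth and higher numbers for weaker inhibition of growth. Compound 1 `CC(=O)CC/C=C(\C)CCC1=C(C)CCCC1(C)C` gives 4940 nM. Compound 2 `C=C1CCC[C@H]2[C@](C)(CC[C@]3(C)CC[C@H]([C@@H](C)C(=O)O)OO3)[C@@H](C)CC[C@]12C` gives 1130 nM, and compound 3 `C=C1CCCC(C)(C)C1CC[C@@]1(C)CC[C@H]([C@@H](C)C(=O)O)OO1` gives 1800 nM. Among these three numbers compound 3 holds the second highest: its nearest neighbour is compound 2, whose number sits within the scatter of it, while compound 1 lies furthest away, beyond the scatter. Among the measured compounds shown here, no pair of measured compounds differs in a single place, so none of these gaps can be tied to one structural change.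

Compound 4 `C=C1CCCC(C)(C)C1CC[C@]1(C)CC[C@@H]([C@@H](C)C(=O)O)OO1` has not yet been measured in this assay. It differs from compound 3 as follows: the two compounds have the same atoms and bonds; at least one stereo element is drawn with a configuration in one of them and without one in the other: 2 of 4 stereo elements differ; a stereocentre at a saturated ring carbon is drawn S in compound 3 and R in compound 4; a stereocentre at a saturated ring carbon is drawn R in compound 3 and S in compound 4. For the measured compounds named here, nothing among the measured compounds isolates the effect of such a change. The step from compound 3 to compound 4 is expected to be a 1.4-fold higher number from compound 3 to compound 4 (0.16 log units; within the scatter), a modest weakening that may not exceed the scatter. Compound 4 is therefore estimated at 2600 nM, within a range from 900 nM to 7500 nM.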

Compound 4, concentration for 50% growth inhibition: 2720 nM
The estimate for compound 4 lay 1.0-fold (0.02 log units) below the measured number, and the stated range covers the measured number.
By their numbers in this assay, from the lowest: compounds 2, 3, 4 and 1 (each within the scatter of the next, the first and the last beyond it).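

Among the compounds shown here, the first measured pair that differs in one place shows that, in this assay, inverting two saturated ring stereocentres together, one from S to R and the other from R to S, gives a 1.5-fold higher number from compound 3 to compound 4 (0.18 log units; within the scatter). With atoms and bonds unchanged, this double inversion therefore does not move the number beyond the scatter. One caution applies to this reading: the fact that one of compounds 3 and 4 is drawn with a defined configuration and the other without, at the place where they differ

The compounds shown do not separate the two ring stereocentres, so the effect of inverting either one alone remains open. Also open, on these data alone, is whether the step would stay this small with a methyl ester or a primary amide in place of the carboxylic acid, or with the same inversion on the core of compound 2.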